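Swapping the amine substituent on a shared pyrimidine-free core

The source may report more compounds than this note shows. Statements on the series, on what has been measured and on what is new or still open speak of the compounds shown alone.

Of the compounds shown here, three share one core and have been tested in a functional assay on SK-OV-3 cells (Homo sapiens) for cytotoxicity, read by MTT assay, with a stated time of 3 days; a lower number here means a stronger inhibitor, a higher number a weaker inhibitor. Compound 1 `N#Cc1c(Cl)nc(SCc2nc3ccccc3[nH]2)nc1-c1ccccc1` gives 3.37 nM. Compound 2 `N#Cc1c(Nc2ccccc2)nc(SCc2nc3ccccc3[nH]2)nc1-c1ccccc1` gives 4.46 nM. Compound 3 `CNc1nc(SCc2nc3ccccc3[nH]2)nc(-c2ccccc2)c1C#N` gives 3 nM. Compound 3 shows the lowest of the three numbers, but its steps to the others are small: a 1.1-fold lower number from compound 1 to compound 3 (0.05 log units; within the scatter) and a 1.5-fold lower number from compound 2 to compound 3 (0.17 log units; within the scatter), so the three compounds cannot be told apart on these data.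

Compound 4 `N#Cc1c(Nc2nccs2)nc(SCc2nc3ccccc3[nH]2)nc1-c1ccccc1` has not yet been measured. It differs from compound 3 in one place: 1,3-thiazol-2-yl in place of methyl on a nitrogen on an aromatic ring.

The step most like this one is the exchange on the same nitrogen between compound 2 and compound 3, where a methyl replaced a phenyl: a 1.5-fold lower number from compound 2 to compound 3 (0.17 log units; within the scatter). The steps from the chloro compound, a 1.3-fold higher number from compound 1 to compound 2 (0.12 log units; within the scatter) and a 1.1-fold lower number from compound 1 to compound 3 (0.05 log units; within the scatter), also stayed within the scatter. Within the data shown here, every change at this position so far has left this assay essentially unmoved, so a similar outcome is expected for an aromatic ring entering in place of the methyl.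

The expected step is therefore a 1.2-fold higher number from compound 3 to compound 4 (0.07 log units; within the scatter), with no direction favoured beyond the scatter. Compound 4 is estimated at 3.5 nM, within a range from 1.5 nM to 8 nM.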

Compound 4, half-maximal inhibitory concentration: 5.81 nM
The estimate for compound 4 lay 1.7-fold (0.22 log units) below the measured number, and the stated range covers the measured number.
By their numbers in this assay, from the lowest: compounds 3, 1, 2 and 4 (each within the scatter of the next).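

In this assay, the nitrogen on the aromatic ring now carries 1,3-thiazol-2-yl, a five-membered aromatic ring with 2 hetero atoms, and the number again stays within the scatter of all three earlier compounds (a 1.9-fold higher number from compound 3 to compound 4 (0.29 log units; within the scatter); a 1.3-fold higher number from compound 2 to compound 4 (0.11 log units; within the scatter); a 1.7-fold higher number from compound 1 to compound 4 (0.24 log units; within the scatter)). The earlier compounds shown here showed this only for methyl and phenyl on that nitrogen, so the result extends the flat picture to an aromatic ring that contains hetero atoms and brings 2 hydrogen-bond acceptors. Across these four compounds, then, neither replacing chloro with one of the three amino groups nor exchanging one nitrogen substituent for another gives a step beyond the scatter, and no measurement shown here offers an explanation for the small differences that do appear.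

As far as these compounds go, what remains open is whether any group on this nitrogen can move the number beyond the scatter, for example a longer chain such as n-butyl, a 2-hydroxyethyl group or a chain ending in a carboxylic acid. All four compounds also keep the same nitrile, phenyl and benzimidazole-bearing thioether parts, so these compounds say nothing about changes made there.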